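Adding a Chloro Group to a Dichlorophenyl Ether

The source may hold more compounds than are shown below. What is called first, only, known or untested is meant among the compounds shown, and "the series" means these compounds.

Compound 1 `NC1=NC2(CCSCC2)N(OCCCOc2cccc(Cl)c2)C(N)=N1` and compound 2 `NC1=NC2(CCSCC2)N(OCCCOc2cccc(Cl)c2Cl)C(N)=N1` were tested in an assay on isolated protein for inhibition of Dihydrofolate reductase (Homo sapiens), read by spectrophotometry, using NADPH, with stated times of 5 s and 6 min, tested at 5 uM; on this read-out higher numbers stand for a stronger effect at the one concentration tested and lower numbers for a weaker effect. Compound 1 gives 88.3% and compound 2 gives 83.8%. The change between them is chloro in place of hydrogen on an aromatic carbon and produced a number 4.5 percentage points lower from compound 1 to compound 2 (within the scatter). Compound 3 `NC1=NC2(CCOCC2)N(OCCCOc2ccc(Cl)c(Cl)c2)C(N)=N1` reaches > 90%, which is a limit of the assay and not a number, consistent with the limit of > 90% in this assay, at which 1 of the 3 values shown sits. The difference between the core of compound 1 and the core of compound 3 is not broken down here. Compound 4 `NC1=NC2(CCOCC2)N(OCCCOc2cc(Cl)c(Cl)cc2Cl)C(N)=N1` differs from compound 3 by chloro in place of hydrogen on an aromatic carbon; this is the same kind of change as that from compound 1 to compound 2, though here the place is ortho to a large group, meta to a chloro group and para to a chloro group, rather than ortho to a chloro group. Since the earlier step of a number 4.5 percentage points lower from compound 1 to compound 2 (within the scatter) lay within the scatter, the step that the limit leaves unreadable from compound 3 to compound 4 is expected to be small. Compound 4 is estimated at 92%.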

Compound 4, a percentage reported as inhibition, at one concentration (the size of the read-out at that concentration, not a potency): > 90%
Compound 4 gave a limit, no number; the forecaster's own chance of this, stated with the estimate: 65%; the middle value lies beyond the limit too.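

No step can be read between compound 3 and compound 4, because each carries a limit of the assay and not a number: the limit of > 90% in this assay, at which 2 of the 4 values shown sit. The compounds shown leave open how far the 2,4,5-trichlorophenyl and 3,4-dichlorophenyl compounds differ in this assay.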